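This account rests on a few compounds, and the source may have more. Where it says the series, first, only, none or still open, it means among the compounds named here.

In an assay on mitochondria from L6 cells (Rattus norvegicus) for activation, with a stated time of 90 min (on this read-out lower numbers stand for an effect already at smaller amounts and higher numbers for an effect only at larger amounts of compound), compound 1 `Fc1ccccc1Nc1nc2nonc2nc1Nc1ccccc1` gives 2200 nM and compound 3 `Fc1ccc(Nc2nc3nonc3nc2Nc2ccccc2F)cc1` gives 2300 nM, a gap of a 1.0-fold higher number from compound 1 to compound 3 (0.02 log units; within the scatter). Compound 2 `Fc1ccccc1Nc1nc2nonc2nc1NCCC(F)(F)F` reaches only a limit of the read-out, > 100000 nM, as the limit of > 100000 nM in this assay, at which 1 of the 3 values shown sits, records. The steps of an at least 45-fold higher number from compound 1 to compound 2 (1.65 log units; beyond the scatter) and an at least 43-fold lower number from compound 2 to compound 3 (1.63 log units; beyond the scatter) show how much 3,3,3-trifluoropropyl in place of an aromatic ring on that nitrogen costs. Compound 3 thus stands level with compound 1, within the scatter of it, while compound 2 sits at the limit. Compound 4 `Fc1ccccc1Nc1nc2nonc2nc1Nc1cccc(F)c1F` differs from compound 3 by 2,3-difluorophenyl in place of 4-fluorophenyl on a nitrogen on an aromatic ring. The aromatic ring stays; of the measured steps only a 1.0-fold higher number from compound 1 to compound 3 (0.02 log units; within the scatter) bears on an added fluoro, and it lay within the scatter, so no step beyond the scatter is expected in this assay. Compound 4 is therefore estimated at 2500 nM, between 900 nM and 7000 nM. That amounts to an expected step of a 1.1-fold higher number from compound 3 to compound 4 (0.04 log units; within the scatter).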

Compound 4, half-maximal effective concentration: 500 nM
Compound 4: middle estimate off by 5.0-fold (0.70 log units), on the high side, and the stated range ends above it.
By their numbers in this assay, from the lowest: compound 4; then compounds 1 and 3 (each within the scatter of the next). At a limit, above all of these: compound 2.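

For the compounds shown here, on the nitrogen on an aromatic ring, the fluoro pattern of the aryl group does matter in this assay: 2,3-difluorophenyl gives a 4.6-fold lower number from compound 3 to compound 4 (0.66 log units; beyond the scatter) and a 4.4-fold lower number from compound 1 to compound 4 (0.64 log units; beyond the scatter), the first steps beyond the scatter among compounds that keep an aromatic ring there. The step to the chain-bearing compound grows to an at least 200-fold lower number from compound 2 to compound 4 (2.30 log units; beyond the scatter), which is only a bound. Compound 2 stands at a limit of the read-out: the limit of > 100000 nM in this assay, at which 1 of the 4 values shown sits.

From the compounds shown here alone, whether the lower number follows the count of fluorines or where they sit stays open. Going by these compounds, how chlorine, methoxy or a nitrile on that ring would read also stays open.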